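The compounds below may be only part of what the source reports. "The series", "measured", "known", "first", "only" and "open" are said of these compounds alone.

Working notes on the series, read throughout in a functional assay on MCF7 cells (Homo sapiens) for inhibition, with a stated time of 48 h, tested at 50 uM (on this read-out lower numbers stand for less inhibition of growth and higher numbers for more inhibition of growth at the one concentration tested), as the only measure. For the measured compounds named here, compound 1 (`C=C[C@@](C)(/C=C/c1ccc(OC(=O)CCCC)cc1)CCC=C(C)C`) gives 25% on this read-out and compound 2 (`C=C[C@@](C)(/C=C/c1ccc(OC(=O)CCCCCCC)cc1)CCC=C(C)C`) gives 12% there, the lower of the two numbers so far. Next comes compound 3 (`C=C[C@@](C)(/C=C/c1ccc(OC(=O)CCCCCCCCCCCCCCC)cc1)CCC=C(C)C`), where the change is octyl in place of hydrogen on a saturated chain carbon, seven bonds along the chain from a carbonyl carbon and reads as octyl in place of hydrogen on a saturated chain carbon, seven bonds along the chain from a carbonyl carbon. Going by the values given here, the one measured step bearing on it is a number 13 percentage points lower from compound 1 to compound 2 (beyond the scatter) for propyl in place of hydrogen on the same kind of chain, a modest step and a single one. A further fall is expected, though a smaller one and possibly within the scatter, because compound 2 at 12% leaves little room. The estimated move is a number 4 percentage points lower from compound 2 to compound 3 (within the scatter) as an expectation only. Compound 3 is estimated at 8% with an expected range from 0% to 20% on this read-out.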

Compound 3, percent growth inhibition at one concentration: 24%
For compound 3 the middle estimate is 16 percentage points below the measured one, outside the stated range (above it).
By their numbers in this assay, from the lowest: compound 2; then compounds 3 and 1 (each within the scatter of the next).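

Across these esters, lengthening the chain does not act in one direction in this assay: a number 13 percentage points lower from compound 1 to compound 2 (beyond the scatter) is followed by a number 12 percentage points higher from compound 2 to compound 3 (beyond the scatter), so the fall seen with the first extension does not carry on with octyl at this position. Undecyl in place of hydrogen, four bonds along the chain from a carbonyl carbon, gives a number 1 percentage points lower from compound 1 to compound 3 (within the scatter), leaving compound 2 apart from two compounds that read alike. No supporting data on hand account for this shape.

Whether the low reading of compound 2 marks a true minimum depends on chains of intermediate length, which the three compounds shown cannot settle. Also open, as far as these compounds go, is how a much shorter acyl chain, or a chain ending in an amine or a carboxylic acid, would read at this position.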